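A few compounds are considered here, and "the series" means these few. Any claim that something is new, unique, unknown or untested is made for them only; others in the source may bear on it.

Measured in an assay on isolated protein (Mus musculus) for inhibition of IL15-IL15 receptor (Homo sapiens), read by resazurin assay, with stated times of 30 min and 2.5 days; on this read-out higher numbers stand for weaker inhibition and lower numbers for stronger inhibition:
compound 1 `Cn1c(Cc2nn(C)c(=O)c3ccccc23)nnc1SCCCCCCCC(=O)Nc1ccc(O)cc1O`: 17000 nM
compound 2 `Cn1c(Cc2nn(C)c(=O)c3ccccc23)nnc1SCCCCCCCC(=O)Nc1ccc(Cl)cc1Cl`: 1900 nM
compound 3 `CC(C)Oc1ccc(NC(=O)CCCCCCCSc2nnc(Cc3nn(C)c(=O)c4ccccc34)n2C)cc1`: 1100 nM

Compound 3 holds the lowest number of the three, but its separation from compound 2 is within the scatter, a 1.7-fold lower number from compound 2 to compound 3 (0.24 log units; within the scatter); only compound 1 stands clearly apart, a 15-fold lower number from compound 1 to compound 3 (1.19 log units; beyond the scatter). Compound 4 `Cn1c(Cc2nn(C)c(=O)c3ccccc23)nnc1SCCCCCCCC(=O)Nc1ccc(Br)cc1Br` differs from compound 3 by 2,4-dibromophenyl in place of 4-isopropoxyphenyl on an amide-type nitrogen. Going by the values given here, the step that bears on this is the one between the dichloro analogue and compound 3, which was within the scatter; the dichloro analogue itself sits well away from the dihydroxy one, an 8.9-fold lower number from compound 1 to compound 2 (0.95 log units; beyond the scatter). A dibromo pair is taken to behave like the dichloro pair, so compound 4 is expected to land close to compound 2, with the step of a 1.6-fold higher number from compound 3 to compound 4 (0.21 log units; within the scatter) estimated as a slight rise, not beyond the scatter. Compound 4 is therefore estimated at 1800 nM, range 700 nM to 5000 nM.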

Compound 4, half-maximal inhibitory concentration: 1500 nM
Compound 4: middle estimate off by 1.2-fold (0.08 log units), on the high side; low and high end bracket the measured number.
By their numbers in this assay, from the lowest: compounds 3, 4 and 2 (each within the scatter of the next); then compound 1.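

In this assay, 2,4-dibromophenyl on an amide-type nitrogen reads level with 4-isopropoxyphenyl (a 1.4-fold higher number from compound 3 to compound 4 (0.13 log units; within the scatter)) and with 2,4-dichlorophenyl (a 1.3-fold lower number from compound 2 to compound 4 (0.10 log units; within the scatter)). A second halogen-bearing aryl group now shares that level, while 2,4-dihydroxyphenyl remains clearly apart (an 11-fold lower number from compound 1 to compound 4 (1.05 log units; beyond the scatter)). Nothing available explains this grouping.

Open, as far as these compounds go, is how an aryl group carrying an amine or a carboxylic acid would read on this nitrogen. Also open, from the compounds shown here alone, is what a longer chain would do to the number.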